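The source may report more compounds than this note shows. Statements on the series, on what has been measured and on what is new or still open speak of the compounds shown alone.

Measured so far in a functional assay on HepG2 cells (Homo sapiens) for antiproliferative activity, read by MTT assay, with a stated time of 48 h; on this read-out higher numbers stand for weaker inhibition and lower numbers for stronger inhibition:

- compound 1 `COc1ccc(-c2c(Nc3ccc(F)cc3)c3ccccc3oc2=O)cc1`: 35500 nM
- compound 2 `COc1ccc(-c2c(Nc3ccc(C)cc3)c3ccccc3oc2=O)cc1`: 59400 nM
- compound 3 `COc1ccc(-c2c(Nc3ccc(F)cc3)c3ccc(O)cc3oc2=O)cc1`: 65600 nM

Compound 4 `COc1ccc(-c2c(Nc3ccc(C)cc3)c3ccc(O)cc3oc2=O)cc1` has not yet been measured.

Compound 3 lies within the scatter of both other compounds, so the three numbers do not separate. Compound 4 differs from it as follows: methyl in place of fluoro on an aromatic carbon. This is methyl in place of fluoro on an aromatic carbon. The same exchange has been measured without the hydroxy group, a 1.7-fold higher number from compound 1 to compound 2 (0.22 log units; within the scatter). Adding the hydroxy group gave a 1.8-fold higher number from compound 1 to compound 3 (0.27 log units; within the scatter). Both steps lie within the scatter, so no change beyond the scatter is expected in this assay, at most a small drift towards weaker inhibition. The expected change is a 1.4-fold higher number from compound 3 to compound 4 (0.16 log units; within the scatter). Compound 4 is estimated at 95000 nM, with an expected range of 50000 nM to 180000 nM.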

Compound 4, half-maximal inhibitory concentration: 88300 nM
For compound 4 the middle estimate is 1.1-fold (0.03 log units) above the measured one, within the range that was stated.
By their numbers in this assay, from the lowest: compounds 1, 2, 3 and 4 (each within the scatter of the next, the first and the last beyond it).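

In this assay the change from 4-fluorophenyl to 4-methylphenyl now reads on a second core as a 1.3-fold higher number from compound 3 to compound 4 (0.13 log units; within the scatter) and stays small with the hydroxy group present: the same change on two cores in this assay, a 1.7-fold higher number (0.22 log units; within the scatter) from compound 1 to compound 2 and a 1.3-fold higher number (0.13 log units; within the scatter) from compound 3 to compound 4, 1.2-fold (0.09 log units) apart, within the scatter of two such steps. The hydroxy group also reads a second time, as a 1.5-fold higher number from compound 2 to compound 4 (0.17 log units; within the scatter) and again stays small: the same change on two cores in this assay, a 1.8-fold higher number (0.27 log units; within the scatter) from compound 1 to compound 3 and a 1.5-fold higher number (0.17 log units; within the scatter) from compound 2 to compound 4, 1.2-fold (0.09 log units) apart, within the scatter of two such steps. Neither change is seen to depend on the other in these four compounds, although together they separate compound 1 and compound 4 by more than the scatter.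

Still open, going by these compounds, is whether an amine or a carboxylic acid on the aromatic carbon carrying the fluoro or methyl group would move the number beyond the scatter. The same question stands for a longer chain in place of the hydroxy group.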